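Compound 4: Hydroxy in Place of Benzoyl

The compounds below may be only part of what the source reports. "The series", "measured", "known", "first", "only" and "open" are said of these compounds alone.

Compound 1 `CC1(C)C=C(n2ccccc2=O)c2cc(C(=O)c3ccccc3)ccc2O1` is the reference point. Going by the values given here, in a functional assay (trachea) with Rattus norvegicus as the target (a higher number here means a more potent compound, by a factor of ten per unit of this negative logarithm, a lower number a less potent compound), compound 1 gives 6.21, the highest of the three numbers measured so far. Compound 2 `CC1(C)C=C(n2ccccc2=O)c2cc(C(=O)c3ccccc3C(F)(F)F)ccc2O1` gives 5.78 in this assay, and compound 3 `CC1(C)C=C(n2ccccc2=O)c2cc(C(=O)c3c(F)cccc3F)ccc2O1` gives 5.99. The step of a number 0.43 log units lower from compound 1 to compound 2 (beyond the scatter) goes with trifluoromethyl in place of hydrogen on an aromatic carbon and lies beyond the scatter, whereas a number 0.22 log units lower from compound 1 to compound 3 (within the scatter), with 2,6-difluorophenyl in place of phenyl on a carbonyl carbon, stays within it, as does a number 0.21 log units higher from compound 2 to compound 3 (within the scatter).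

Compound 4 `CC1(C)C=C(n2ccccc2=O)c2cc(O)ccc2O1` differs from compound 1 in one place: hydroxy in place of benzoyl on an aromatic carbon. Neither measured step bears directly on this change, because a number 0.43 log units lower from compound 1 to compound 2 (beyond the scatter) and a number 0.22 log units lower from compound 1 to compound 3 (within the scatter) came from changes that altered only the ring of the benzoyl while keeping the whole group in place. Here the entire benzoyl is lost and only a hydroxy remains, a far larger change than either of those, so a step beyond the scatter, downward, is expected rather than the modest shifts seen so far. Compound 4 is therefore estimated to give 5.2 in this assay, with a range from 4.4 to 6. The expected step is a number 1.01 log units lower from compound 1 to compound 4 (beyond the scatter).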

Compound 4, logarithm of the reciprocal of the active concentration, log(1/C): 5.31
Compound 4: the middle estimate sits 0.11 log units below what was measured, within the range that was stated.
By their numbers in this assay, from the lowest: compound 4; then compounds 2, 3 and 1 (each within the scatter of the next, the first and the last beyond it).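

In this assay the step for hydroxy in place of benzoyl is a number 0.90 log units lower from compound 1 to compound 4 (beyond the scatter) and so shows that this position responds clearly when the whole group is lost. Changes to the ring of the benzoyl had given smaller steps, with a number 0.43 log units lower from compound 1 to compound 2 (beyond the scatter) for trifluoromethyl and a number 0.22 log units lower from compound 1 to compound 3 (within the scatter) for the two fluorines. The compounds now show that the benzoyl adds to the number here, but also that compound 4 keeps a measurable reading without it. No measurement at hand says what lies behind the fall.

The benzoyl has two parts, a carbonyl and a phenyl ring, and the compounds shown do not say which of them matters more: an acetyl group would keep the carbonyl without the ring, and a benzyl group would keep the ring without the carbonyl. On these data alone, whether the hydroxy itself contributes to the reading of compound 4 also stays open, and a methoxy group or an amine at the same aromatic carbon would be the direct comparisons.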